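From methyl to propyl on compound 1

The source may hold more compounds than are shown below. What is called first, only, known or untested is meant among the compounds shown, and "the series" means these compounds.

Compound 1 `CN1CCN(c2ccc(S(=O)(=O)Oc3cc(Cl)c(Cl)cc3Cl)cc2)C1=O` gives 630 nM
Compound 2 `CN1CCN(c2ccc(S(=O)(=O)Oc3ccc(F)cc3)cc2)C1=O` gives > 100000 nM (a limit)

Among the compounds with values here, in a functional assay on MCF7 cells (Homo sapiens) for antiproliferative activity, read by sulforhodamine B assay, with a stated time of 48 h (a higher number here means a weaker inhibitor, a lower number a stronger inhibitor), compound 1 gives 630 nM as the only true number so far. Compound 2 reads > 100000 nM and that is a limit of the assay, not a number. Compound 3 `CCCN1CCN(c2ccc(S(=O)(=O)Oc3cc(Cl)c(Cl)cc3Cl)cc2)C1=O` keeps the core of compound 1 with one change, ethyl in place of hydrogen on a saturated chain carbon bound to an amide-type nitrogen in a ring (methyl to propyl). Within the data shown here, no measured pair shows what such a change does, so in this assay only a small step towards weaker is expected, possibly none beyond the scatter. The estimated change is a 1.3-fold higher number from compound 1 to compound 3 (0.10 log units; within the scatter) on this reading. Compound 3 is expected at 800 nM with an estimated range from 250 nM to 3000 nM here.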

Compound 3, half-maximal inhibitory concentration: 13000 nM
Compound 3: middle estimate off by 16-fold (1.21 log units), on the low side; the measured number lies above the stated range.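

Going from methyl to propyl at this place brings a 21-fold higher number from compound 1 to compound 3 (1.31 log units; beyond the scatter) in this assay. Within the data shown here, this is the first single-change comparison at this position, and it shows that the position is sensitive, with just the added ethyl enough to weaken the compound markedly. Nothing measured here explains the loss.

On these data alone, whether ethyl would fall between methyl and propyl remains open, as does whether a longer chain such as butyl would weaken the compound further. It is also unknown how a chain ending in an amine or a carboxylic acid would fare at this position.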